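Amide aryl swap on two methyl-isomer cores: microsomal half-life

The source may report more compounds than this note shows. Statements on the series, on what has been measured and on what is new or still open speak of the compounds shown alone.

The series pairs two cores that carry the same atoms joined differently: compound 1 `CNc1nc(NCc2ccc(NC(=O)c3ccc(F)cc3)cc2)c2ccc(C)cc2n1` and compound 2 `CNc1nc(NCc2ccc(NC(=O)c3ccc(F)cc3)cc2)c2cc(C)ccc2n1`; the difference between the two cores is not broken down here. On the core of compound 1, compound 3 `CNc1nc(NCc2ccc(NC(=O)c3ccc(Cl)nc3)cc2)c2ccc(C)cc2n1` carries the change (6-chloropyridin-3-yl in place of 4-fluorophenyl on a carbonyl carbon). In an in vitro ADME assay on microsomes from liver (Rattus norvegicus) for metabolic stability (a lower number here means that the compound disappears faster, a higher number that the compound lasts longer), compound 1 gives > 0.5 h, which is a limit of the assay rather than a number. In this assay compound 3 gives 0.133 h. The step of an at least 3.7-fold lower number from compound 1 to compound 3 (0.57 log units; beyond the scatter) is therefore only a lower bound, because compound 1 sits at the limit of > 0.5 h in this assay, at which 1 of the 3 values shown sits. In this assay compound 2 gives 0.1 h; its value and that of compound 3 lie within the scatter of each other.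

Compound 4 `CNc1nc(NCc2ccc(NC(=O)c3ccc(Cl)nc3)cc2)c2cc(C)ccc2n1` is not yet measured in this assay. It differs from compound 2 by 6-chloropyridin-3-yl in place of 4-fluorophenyl on a carbonyl carbon, the same change that separates compound 1 from compound 3. On the core of compound 1 that change gave an at least 3.7-fold lower number from compound 1 to compound 3 (0.57 log units; beyond the scatter), and the same direction is expected on the core of compound 2, though compound 2 starts from a much lower number, so the room downward is uncertain. The step expected from compound 2 to compound 4 is a 2.0-fold lower number from compound 2 to compound 4 (0.30 log units; within the scatter). In this assay compound 4 is expected to give 0.05 h, with a range from 0.02 h to 0.13 h.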

Compound 4, half-life in the Rattus norvegicus assay: 0.217 h
Beside the measured number, compound 4's estimate is 4.3-fold (0.64 log units) below it; the whole stated range lies below it.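

On the core of compound 2, 6-chloropyridin-3-yl in place of 4-fluorophenyl on a carbonyl carbon gives, in the Rattus norvegicus assay, a 2.2-fold higher number from compound 2 to compound 4 (0.34 log units; beyond the scatter), which runs opposite to the earlier step on the core of compound 1, so this change does not carry over between the two cores in direction: the same change on two cores in the Rattus norvegicus assay, an at least 3.7-fold lower number (0.57 log units; beyond the scatter) from compound 1 to compound 3 and a 2.2-fold higher number (0.34 log units; beyond the scatter) from compound 2 to compound 4, at least 8.1-fold (0.91 log units) apart, beyond the scatter of two such steps. Compound 1 stands at a limit of the assay and not at a number, so the earlier step and the gap between the steps are bounds rather than exact sizes: the limit of > 0.5 h in the Rattus norvegicus assay, at which 1 of the 4 values shown sits. Two pairs set no rule for any further core and give no reason for the reversal. In a physicochemical assay for solubility, at pH 7.4 (a higher number here means a more soluble compound, a lower number a less soluble compound), compound 2 gives 10 ug/mL and compound 4 gives 3 ug/mL, so on the core of compound 2 the same change also goes with a lower number: the measured solubility of compound 2, 10 ug/mL, and of compound 4, 3 ug/mL, a 3.3-fold lower number (0.52 log units; beyond the scatter).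

The compounds shown leave open whether the reversal belongs to the chlorine, to the ring nitrogen or to the two groups as whole units; an unsubstituted phenyl or a pyridin-3-yl without the chlorine on the carbonyl carbon, on both cores, would separate these. Also open, going by these compounds, is whether a saturated ring such as cyclohexyl on the same carbonyl carbon would follow either core.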